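Swapping Cyclopentyl for Hydroxyethyl on an Amine Nitrogen

The compounds below may be only part of what the source reports. "The series", "measured", "known", "first", "only" and "open" are said of these compounds alone.

Within the data shown here, compound 2 `c1ccc(Cn2nnc3c(NC4CCCC4)nc(-c4ccccc4)nc32)cc1` holds the lower of the two numbers measured so far in an assay on Cerebral cortex for displacement of a labelled ligand from adenosine receptor A1 (Bos taurus) (a lower number here means a stronger inhibitor, a higher number a weaker inhibitor), where compound 2 gives 11 nM. Among the measured compounds shown here, its only measured neighbour, compound 1 `CNc1nc(-c2ccccc2)nc2c1nnn2Cc1ccccc1`, differs at the nitrogen on the aromatic ring, and in this assay compound 1 gives 353 nM; the step of a 32-fold lower number from compound 1 to compound 2 (1.51 log units; beyond the scatter) is the one measured step in this set. Compound 3 `OCCNc1nc(-c2ccccc2)nc2c1nnn2Cc1ccccc1` is not yet measured and differs from compound 2 by 2-hydroxyethyl in place of cyclopentyl on a nitrogen on an aromatic ring. That measured step bears directly on it, because the large fall in number a 32-fold lower number from compound 1 to compound 2 (1.51 log units; beyond the scatter) came from enlarging the group on this very nitrogen, and compound 3 returns to a short chain there. The step of an 18-fold higher number from compound 2 to compound 3 (1.26 log units; beyond the scatter) is therefore expected to run upward, back toward the number of compound 1. Compound 3 is estimated at 200 nM in this assay, with a range from 50 nM to 800 nM.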

Compound 3, inhibition constant: 38 nM
Compound 3: middle estimate off by 5.3-fold (0.72 log units), on the high side, outside the stated range (below it).
By their numbers in this assay, from the lowest: compound 2; then compound 3; then compound 1.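

Until now, this nitrogen had shown only that cyclopentyl gives a far lower number than methyl. The open-chain 2-hydroxyethyl shows that a ring is not needed for a low number in this assay: the cost of losing the ring is limited to a 3.5-fold higher number from compound 2 to compound 3 (0.54 log units; beyond the scatter), while adding hydroxymethyl to the methyl group gives a 9.3-fold lower number from compound 1 to compound 3 (0.97 log units; beyond the scatter), which leaves compound 3 nearer to compound 2 than to compound 1. Nothing available explains these numbers.

The compounds shown leave open whether the gain over methyl goes with the added carbon or with the hydroxyl, a question that ethyl on this nitrogen would help to separate. They also do not show how a longer chain such as 3-hydroxypropyl, or an amine such as 2-aminoethyl, would compare with cyclopentyl.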